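Working notes: cytotoxicity across compounds 1 to 3

The source may report more compounds than this note shows. Statements on the series, on what has been measured and on what is new or still open speak of the compounds shown alone.

Measured compounds:
Compound 1 `CS(=O)(=O)CCCn1c(Cn2c(=O)n(C3CN(S(C)(=O)=O)C3)c3ccncc32)cc2cc(Cl)ccc21`. In an ADME assay on HeLa cells (Homo sapiens) for cytotoxicity, read by ATP content, with a stated time of 3 days (on this read-out higher numbers stand for lower toxicity in this test and lower numbers for higher toxicity in this test), compound 1 gives > 50000 nM, which is a limit of the assay.
Compound 2 `CS(=O)(=O)CCCn1c(Cn2c(=O)[nH]c3ccncc32)cc2cc(Cl)ccc21`. In this assay compound 2 gives > 50000 nM, which is a limit of the assay.

Compound 2 therefore stands at the top limit of this assay rather than at a measured number, and the same holds for the whole set so far (the limit of > 50000 nM in this assay, at which 2 of the 2 values shown sit). Within the data shown here, the only step between measured compounds, a step that the two limits leave unreadable from compound 1 to compound 2, is unreadable because both of its ends are limits.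

Compound 3 `CC1(n2c(=O)n(Cc3cc4cc(Cl)ccc4n3CCCS(C)(=O)=O)c3cnccc32)CC1` differs from compound 2 by 1-methylcyclopropyl in place of hydrogen on an aromatic nitrogen. Among the measured compounds shown here, the one step that bears on this change, a step that the two limits leave unreadable from compound 1 to compound 2, gives no readable size, so it supplies no basis for expecting a step in this assay beyond the scatter in either direction. The expected step from compound 2 to compound 3 is accordingly a number no higher from compound 2 to compound 3 (the limit leaves the size open). Compound 3 is estimated at 50000 nM, with a range from 15000 nM to 150000 nM, and most likely returned as a limit.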

Compound 3, half-maximal cytotoxic concentration: > 50000 nM
Compound 3 ended at the assay's limit; the forecaster's own chance of this, stated with the estimate: 75%; the middle value lies on the limit itself.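

In this assay compound 3 gives > 50000 nM, which is a limit of the assay. No step among compound 1, compound 2 and compound 3 can be read, because every value is a limit: the limit of > 50000 nM in this assay, at which 3 of the 3 values shown sit.

The compounds shown leave open whether the group on the aromatic nitrogen changes the half-maximal cytotoxic concentration at all.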